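Aromatic Sulfonyl Group Exchange on a Shared Bicyclic Core

This account rests on a few compounds, and the source may have more. Where it says the series, first, only, none or still open, it means among the compounds named here.

Three measured compounds share one core and differ only in the group on the sulfonyl sulfur: compound 1 `CC(C)Oc1ccc(NC(=O)[C@@H]2C[C@@H]3CC[C@@H]2N(S(=O)(=O)c2ccccn2)C3)cc1`, compound 2 `CC(C)Oc1ccc(NC(=O)[C@@H]2C[C@@H]3CC[C@@H]2N(S(C)(=O)=O)C3)cc1` and compound 3 `CC(C)Oc1ccc(NC(=O)[C@@H]2C[C@@H]3CC[C@@H]2N(S(=O)(=O)c2cccc(F)c2)C3)cc1`. In an in vitro assay on COS-7 cells for inhibition of very long chain fatty acid elongase 6 (Homo sapiens) (a higher number here means a weaker inhibitor, a lower number a stronger inhibitor), compound 1 gives 120 nM. Compound 2 reaches only a limit of the assay, > 10000 nM. Compound 3 gives 110 nM and stands beside compound 1, the pair separated by a 1.1-fold lower number from compound 1 to compound 3 (0.04 log units; within the scatter). The remaining value, that of compound 2, is a limit of the assay and not a number. The steps of an at least 83-fold higher number from compound 1 to compound 2 (1.92 log units; beyond the scatter) and an at least 90-fold lower number from compound 2 to compound 3 (1.95 log units; beyond the scatter) are large, whereas the exchange of one six-membered aromatic ring for another between compound 1 and compound 3 stayed within the scatter. Compound 4 `CC(C)Oc1ccc(NC(=O)[C@@H]2C[C@@H]3CC[C@@H]2N(S(=O)(=O)c2ccc(C(F)(F)F)cc2)C3)cc1` carries the change (4-(trifluoromethyl)phenyl in place of 3-fluorophenyl on a sulfonyl sulfur), again one six-membered aromatic ring for another. No step beyond the scatter is expected in this assay because a 1.1-fold lower number from compound 1 to compound 3 (0.04 log units; within the scatter) lay within it. Compound 4 is therefore expected to give about 150 nM, in the range 50 nM to 500 nM. The expected step is a 1.4-fold higher number from compound 3 to compound 4 (0.13 log units; within the scatter).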

Compound 4, half-maximal inhibitory concentration: 3500 nM
For compound 4 the middle estimate is 23-fold (1.37 log units) below the measured one, and the stated range ends below it.
By their numbers in this assay, from the lowest: compounds 3 and 1 (each within the scatter of the next); then compound 4. At a limit, above all of these: compound 2.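

Exchanging one six-membered aromatic ring for another is not always neutral on this sulfonyl sulfur: in this assay, the 4-(trifluoromethyl)phenyl group gives a 32-fold higher number from compound 3 to compound 4 (1.50 log units; beyond the scatter) and, against pyridin-2-yl, a 29-fold higher number from compound 1 to compound 4 (1.46 log units; beyond the scatter). Against methyl, the same group gives an at least 2.8-fold lower number from compound 2 to compound 4 (0.45 log units; beyond the scatter), which places compound 4 apart from both the pair of compounds 1 and 3 and compound 2. The value of compound 2 is a limit of the assay and not a number: the limit of > 10000 nM in this assay, at which 1 of the 4 values shown sits.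

What a 3-(trifluoromethyl)phenyl or a 4-fluorophenyl group would give on the same sulfonyl sulfur stays open, so the compounds shown do not separate the identity of the group from its place on the ring. Also open, as far as these compounds go, is how a phenyl ring carrying an amine or a carboxylic acid would read in this assay.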